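The source may report more compounds than this note shows. Statements on the series, on what has been measured and on what is new or still open speak of the compounds shown alone.

Measured so far in a functional assay on HepG2 cells (Homo sapiens) for antiproliferative activity, read by MTT assay, with a stated time of 72 h; on this read-out lower numbers stand for stronger inhibition and higher numbers for weaker inhibition:
- compound 1, `NC1=NC2(CCSCC2)N(OCCCOc2ccc(Cl)cc2)C(N)=N1`: compound 1 gives 1100 nM.
- compound 2, `NC1=NC2(CCSCC2)N(OCCCOc2cc(Cl)c(Cl)cc2Cl)C(N)=N1`: compound 2 gives > 100000 nM, which is a limit of the assay and not a number.
- compound 3, `NC1=NC2(CCSCC2)N(OCCCOc2ccccc2Cl)C(N)=N1`: compound 3 gives 80 nM.

For the measured compounds named here, compound 3 holds the lowest of the two real numbers; the only other number belongs to compound 1, and the step from compound 1 to compound 3 reads a 14-fold lower number from compound 1 to compound 3 (1.14 log units; beyond the scatter). Compound 2 sits at the assay ceiling, (the limit of > 100000 nM in this assay, at which 1 of the 3 values shown sits), so the step of an at least 90-fold higher number from compound 1 to compound 2 (1.95 log units; beyond the scatter) and the step of an at least 1200-fold lower number from compound 2 to compound 3 (3.09 log units; beyond the scatter) are both open-ended.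

The next compound, compound 4, `NC1=NC2(CCSCC2)N(OCCCOc2cccc(Br)c2)C(N)=N1`, differs from compound 3 by 3-bromophenyl in place of 2-chlorophenyl on an oxygen on a saturated carbon. Going by the values given here, no measured step exchanges chlorine for bromine, and none places a halogen as 3-bromophenyl does, so the bearing of the known steps is indirect. Still, a 14-fold lower number from compound 1 to compound 3 (1.14 log units; beyond the scatter) shows that a single chlorine on the phenoxy ring gives a number that depends strongly on which phenyl it forms, and an at least 90-fold higher number from compound 1 to compound 2 (1.95 log units; beyond the scatter) shows that piling on chlorines drives the number to the limit. Compound 4 keeps a single halogen, so the expectation is a number between compound 3 and compound 1: a moderate rise, a 4.4-fold higher number from compound 3 to compound 4 (0.64 log units; beyond the scatter). Compound 4 is therefore estimated at 350 nM, with a range from 80 nM to 2000 nM.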

Compound 4, half-maximal inhibitory concentration: 90 nM
Compound 4: middle estimate off by 3.9-fold (0.59 log units), on the high side; the measured number falls inside the stated range.
By their numbers in this assay, from the lowest: compounds 3 and 4 (each within the scatter of the next); then compound 1. At a limit, above all of these: compound 2.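

In this assay, the step of a 1.1-fold higher number from compound 3 to compound 4 (0.05 log units; within the scatter) lies within the scatter, so at this place, on an oxygen on a saturated carbon, 3-bromophenyl and 2-chlorophenyl cannot be told apart, even though the change swaps the halogen and alters its place on the ring in a single move. The step of a 12-fold lower number from compound 1 to compound 4 (1.09 log units; beyond the scatter) lies beyond the scatter, so among the compounds with a single halogen, compounds 3 and 4 stand together and compound 1, with 4-chlorophenyl, stands apart, which means that a single halogen alone does not fix the number. The step of an at least 1100-fold lower number from compound 2 to compound 4 (3.04 log units; beyond the scatter) is open-ended, as compound 2 gives a limit of the assay and not a number: the limit of > 100000 nM in this assay, at which 1 of the 4 values shown sits.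

Since compounds 3 and 4 differ in both halogen and ring place, the two effects remain unseparated, and 3-chlorophenyl or 2-bromophenyl would be needed to pull them apart. Also open, as far as these compounds go, is whether a halogen is needed at all, which plain phenyl or a phenyl carrying methoxy or nitrile would address, and how the number responds to a longer chain between the oxygen atoms.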